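A few compounds are considered here, and "the series" means these few. Any claim that something is new, unique, unknown or untested is made for them only; others in the source may bear on it.

Measured so far in an ADME assay on MRC5 cells (Homo sapiens) for cytotoxicity, read by fluorescence, with a stated time of 24 h; on this read-out lower numbers stand for stronger inhibition and higher numbers for weaker inhibition:
Compound 1 `Nc1ccccc1C(=O)N/N=C/c1ccc2no[n+]([O-])c2c1`: 122000 nM
Compound 2 `O=C(N/N=C/c1ccc2no[n+]([O-])c2c1)c1ccccc1`: 130000 nM

Compound 2, at 130000 nM, stands level with compound 1, as the two numbers cannot be told apart. The next compound to be tested is compound 3 `Nc1cccc(C(=O)N/N=C/c2ccc3no[n+]([O-])c3c2)c1`. It has amino in place of hydrogen on an aromatic carbon of the six-membered aromatic ring of carbon only, meta to a large group (amino in place of hydrogen on an aromatic carbon). In short, phenyl becomes 3-aminophenyl.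

Among the measured compounds shown here, only one measured step bears on this change: a 1.1-fold higher number from compound 1 to compound 2 (0.03 log units; within the scatter). That step removes an amino group, so it runs opposite to the change made here, and it stays within the scatter. For the measured compounds named here, compound 1 carries its amino group elsewhere on the ring, and no measured compound carries it at the place found in compound 3, so this is only a rough guide. On this evidence, no shift beyond the scatter is expected in this assay. The estimated step is a 1.0-fold lower number from compound 2 to compound 3 (0.02 log units; within the scatter). Compound 3 is expected at about 125000 nM, with an estimated range of 60000 nM to 260000 nM.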

Compound 3, half-maximal inhibitory concentration: 82100 nM
Beside the measured number, compound 3's estimate is 1.5-fold (0.18 log units) above it; measured number inside the range.
By their numbers in this assay, from the lowest: compounds 3, 1 and 2 (each within the scatter of the next).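

In this assay, among the compounds shown here, adding amino to the ring, so that phenyl becomes 3-aminophenyl, gives a 1.6-fold lower number from compound 2 to compound 3 (0.20 log units; within the scatter), which adds a second ring place to the single amino comparison available before and again yields no shift clear of the usual scatter. Moving the group, with 3-aminophenyl in place of 2-aminophenyl, gives a 1.5-fold lower number from compound 1 to compound 3 (0.17 log units; within the scatter), so at the two ring places tested, the location of the amino group makes no difference that can be told from the scatter, and the three compounds remain level despite the differences in their printed numbers. Nothing on hand offers an explanation for these small differences.

The compounds shown leave open whether a carboxylic acid or a methoxy group, in place of the amino group on the same aromatic carbon, would move the number beyond the scatter, which would show whether this ring tolerates other groups as well as it tolerates amino. They also leave open how far the number depends on the shared core, which stays the same in all three compounds.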